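Saturating the Chain of Compound 2

The source may report more compounds than this note shows. Statements on the series, on what has been measured and on what is new or still open speak of the compounds shown alone.

Of the compounds shown here, two have numbers so far in a functional assay on MCF7 cells (Homo sapiens) for antiproliferative activity, read by MTT assay, with a stated time of 48 h; on this read-out lower numbers stand for stronger inhibition and higher numbers for weaker inhibition. Compound 1 (`COc1cc(CNC(=O)CCCCCCC(C)C)ccc1OCCCCOc1ccc(C(N)=S)cc1`) gives 4990 nM, and compound 2 (`COc1cc(CNC(=O)CCCC/C=C/C(C)C)ccc1OCCCCOc1ccc(-c2cc(=S)ss2)cc1`) gives 36400 nM. Compound 2 thus has the higher of the two numbers, and so it is the weaker inhibitor of the pair, by a gap beyond the usual scatter. These two compounds differ in more than one place, so their gap cannot be pinned on any single feature.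

Compound 3 (`COc1cc(CNC(=O)CCCCCCC(C)C)ccc1OCCCCOc1ccc(-c2cc(=S)ss2)cc1`) departs from compound 2 in one place: isopentyl in place of 3-methylbut-1-en-1-yl on a saturated chain carbon, four bonds along the chain from a carbonyl carbon. Put simply, isopentyl stands in place of 3-methylbut-1-en-1-yl on a saturated chain carbon, four bonds along the chain from a carbonyl carbon, so the chain loses its double bond. Going by the values given here, no measured pair shows this change on its own, which leaves the expectation on thin ground. No step beyond the scatter is expected in this assay. The estimated change is small, a 1.2-fold lower number from compound 2 to compound 3 (0.08 log units; within the scatter), starting from the value of compound 2. Compound 3 is expected at about 30000 nM, with an estimated range of 12000 nM to 75000 nM.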

Compound 3, half-maximal inhibitory concentration: 49500 nM
Beside the measured number, compound 3's estimate is 1.7-fold (0.22 log units) below it; low and high end bracket the measured number.
By their numbers in this assay, from the lowest: compound 1; then compounds 2 and 3 (each within the scatter of the next).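

In this assay, saturating the chain gives a step (a 1.4-fold higher number from compound 2 to compound 3 (0.13 log units; within the scatter)) that does not separate the two compounds, so on this saturated chain carbon, four bonds along the chain from a carbonyl carbon, swapping 3-methylbut-1-en-1-yl for isopentyl makes no readable difference. Compound 3 also shares its chain with compound 1, so the two now differ in one place only, and the group on the aromatic carbon carries a clear gap (a 9.9-fold higher number from compound 1 to compound 3 (1.00 log units; beyond the scatter)), with the five-membered aromatic ring group giving the weaker result. Nothing measured here explains either step.

The compounds shown leave open whether the double bond would also make no readable difference in a compound that carries the smaller group of compound 1 on the aromatic carbon. They also leave open how far the chain can be altered before the number moves, for instance with a much shorter chain or with an amine or a carboxylic acid at its end.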